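This account rests on a few compounds, and the source may have more. Where it says the series, first, only, none or still open, it means among the compounds named here.

Compound 1, `CCCCNC(=O)C1C(C(=O)O)[C@@H]2CC[C@H]1O2`, was examined in an ADME assay on BE(2)-C cells (Homo sapiens) for cytotoxicity, read by MTT assay, with a stated time of 72 h (on this read-out higher numbers stand for weaker inhibition of growth and lower numbers for stronger inhibition of growth), and in that assay compound 1 gives 10000 nM. Its companion, compound 2, `CCc1ccccc1NC(=O)C1C(C(=O)O)[C@@H]2CC[C@H]1O2`, carries an aromatic amide substituent in place of the butyl chain; in this assay compound 2 gives 10000 nM. Compound 1 thus stands level with compound 2 at the digits shown, the two values lying within the usual scatter of each other, so nothing separates them.

Compound 3, `CCCNC(=O)C1C(C(=O)O)[C@@H]2CC[C@H]1O2`, has not yet been measured in this assay. Relative to compound 1 it shows one change: hydrogen in place of methyl on a saturated chain carbon, three bonds along the chain from an amide-type nitrogen. Going by the values given here, no measured pair spans such a step, so only the two values above guide the expectation. The step from compound 1 to compound 3 is expected to be no change at the digits printed from compound 1 to compound 3 (within the scatter), that is, none beyond the scatter. Compound 3 is therefore estimated to give 10000 nM in this assay, with a range of 5000 nM to 20000 nM.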

Compound 3, concentration for 50% growth inhibition: 10000 nM
Compound 3: middle estimate and measured number agree at the digits printed, within the range that was stated.
By their numbers in this assay, from the lowest: compounds 1, 2 and 3 (each within the scatter of the next).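

In this assay, hydrogen in place of methyl on a saturated chain carbon, three bonds along the chain from an amide-type nitrogen, gives no change at the digits printed from compound 1 to compound 3 (within the scatter), the first step read at this place on the chain. Within this pair, therefore, the butyl and propyl chains are not told apart by this read-out, and the methyl that leaves can be given up here without a change beyond the scatter. No supporting measurement bears on this result.

The compounds shown leave open whether a longer chain, or an amine or a hydroxyl group carried on the chain, would shift the value away from that of compound 3, which gives 10000 nM. They also leave open whether an ester in place of the carboxylic acid would move the read-out in this assay at all.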